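Phenyl in place of hydrogen on the chain carbon of compound 3

The source may report more compounds than this note shows. Statements on the series, on what has been measured and on what is new or still open speak of the compounds shown alone.

Measured so far in a functional assay on the whole organism (arterial blood) with Rattus norvegicus as the target; on this read-out lower numbers stand for an effect already at smaller amounts and higher numbers for an effect only at larger amounts of compound:
compound 1 `Cc1nc2cnccc2n1C1CCN(C(=O)CC(c2ccccc2)c2ccccc2)CC1` gives 0.41 mg/kg;
compound 2 `Cc1nc2cnccc2n1CC1CCN(C(=O)CC(C)c2ccccc2)CC1` gives 0.033 mg/kg;
compound 3 `Cc1nc2cnccc2n1CC1CCN(C(=O)CCc2ccccc2)CC1` gives > 5 mg/kg.

Compound 3 stands at the edge of the numbers: its value is a limit of the assay, not a measurement. It sits at the limit of > 5 mg/kg in this assay, at which 1 of the 3 values shown sits. Compound 4 `Cc1nc2cnccc2n1CC1CCN(C(=O)CC(c2ccccc2)c2ccccc2)CC1` is not yet measured; it differs from compound 3 by phenyl in place of hydrogen on a saturated chain carbon bound to an aromatic carbon and a saturated chain carbon. Going by the values given here, the one measured step bearing on this position is an at least 150-fold higher number from compound 2 to compound 3 (2.18 log units; beyond the scatter). Putting a group back on this carbon is therefore expected to lower the number, and compound 1, which also carries phenyl on a saturated chain carbon bound to an aromatic carbon, gives 0.41 mg/kg in this assay. For compound 4 the step of an at least 25-fold lower number from compound 3 to compound 4 (1.39 log units; beyond the scatter) is expected. Compound 4 is estimated at 0.2 mg/kg, within 0.05 mg/kg to 0.8 mg/kg.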

Compound 4, dose for 50% inhibition: 0.0086 mg/kg
Estimate against measurement, compound 4: 23-fold (1.37 log units) above; the whole stated range lies above it.
By their numbers in this assay, from the lowest: compound 4; then compound 2; then compound 1. At a limit, above all of these: compound 3.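

Phenyl on this saturated chain carbon gives an at least 580-fold lower number from compound 3 to compound 4 (2.76 log units; beyond the scatter), so the position takes a whole aromatic ring and not only methyl. Phenyl also goes beyond methyl here, with a 3.8-fold lower number from compound 2 to compound 4 (0.58 log units; beyond the scatter), and the group on the saturated ring carbon counts for more than this last change, with a 48-fold lower number from compound 1 to compound 4 (1.68 log units; beyond the scatter). Compound 3 gives > 5 mg/kg, which is a limit of the assay and not a number.

Open, on these data alone, is whether an amine or a carboxylic acid on this chain carbon would keep the number low. Also open, as far as these compounds go, is whether a longer chain in place of phenyl would do so.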